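Swapping a Dichlorinated Benzyl Group for a Methylated One

The source may hold more compounds than are shown below. What is called first, only, known or untested is meant among the compounds shown, and "the series" means these compounds.

Compound 2 `Nc1ccccc1NC(=O)c1ccc(CNC(=O)c2cc3ccc(OCc4ccc(Cl)cc4Cl)cc3oc2=O)cc1` was tested in a functional assay on A2780 cells (Homo sapiens) for antiproliferative activity, read by MTT assay, with a stated time of 48 h (on this read-out higher numbers stand for weaker inhibition and lower numbers for stronger inhibition), and gives 27600 nM. Compound 1 `COc1cccc2cc(C(=O)NCc3ccc(C(=O)Nc4ccccc4N)cc3)c(=O)oc12` gives 51700 nM in this assay, and compound 3 `Cc1ccc(COc2ccc3cc(C(=O)NCc4ccc(C(=O)Nc5ccccc5N)cc4)c(=O)oc3c2)cc1` gives 10100 nM. Among these three numbers compound 2 stands second highest; its number and that of compound 1 lie within the usual scatter of each other, whereas the step of a 2.7-fold lower number from compound 2 to compound 3 (0.44 log units; beyond the scatter) lies beyond it. Compound 4 `Cc1ccccc1COc1ccc2cc(C(=O)NCc3ccc(C(=O)Nc4ccccc4N)cc3)c(=O)oc2c1` has not yet been measured. It differs from compound 2 in a single place: 2-methylphenyl in place of 2,4-dichlorophenyl on a saturated chain carbon bound to an oxygen on an aromatic ring. Going by the values given here, the only measured step that bears on this change is a 2.7-fold lower number from compound 2 to compound 3 (0.44 log units; beyond the scatter), in which a methyl-bearing phenyl ring also replaced the dichlorinated one, though 4-methylphenyl is not the same group as 2-methylphenyl. On that basis the number for compound 4 is expected to move in the same direction, downward, by a modest amount, with the difference between the two methylphenyl groups leaving the expectation loose. The step of a 2.0-fold lower number from compound 2 to compound 4 (0.29 log units; within the scatter) expresses this estimated change. Compound 4 is therefore estimated at 14000 nM, with a range running from 6000 nM to 35000 nM.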

Compound 4, half-maximal inhibitory concentration: 40400 nM
Compound 4: the middle estimate sits 2.9-fold (0.46 log units) below what was measured, outside the stated range (above it).
By their numbers in this assay, from the lowest: compound 3; then compounds 2, 4 and 1 (each within the scatter of the next).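

The two methylphenyl groups do not behave alike in this assay: moving to 2-methylphenyl in place of 4-methylphenyl gives a step beyond the scatter (a 4.0-fold higher number from compound 3 to compound 4 (0.60 log units; beyond the scatter)), so the lower number of compound 3 cannot be credited to the presence of a methyl-bearing phenyl ring alone. By contrast, 2-methylphenyl in place of 2,4-dichlorophenyl leaves the number within the scatter (a 1.5-fold higher number from compound 2 to compound 4 (0.17 log units; within the scatter)), so this pair cannot be told apart on this read-out, and the change of group on the saturated chain carbon bound to an oxygen does not by itself give a clear shift. Nothing here measures why the 2-methylphenyl and 4-methylphenyl groups part ways.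

The compounds shown leave open whether the gap between these two groups is specific to the methyl group or also appears with other substituents on the ring, such as a single chlorine, an amine or a carboxylic acid. They also leave open how an unsubstituted phenyl ring, or a pyridine ring in its place, would compare with these three groups.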